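Adding a methyl to the arylpiperazine end of compound 2

This account rests on a few compounds, and the source may have more. Where it says the series, first, only, none or still open, it means among the compounds named here.

Of the compounds shown here, two have been measured so far. Compound 1 `Cc1ccc(N2CCN(CCCCOc3ccc4c(=O)cc(-c5ccccc5)oc4c3)CC2)cc1` gives 195 nM in a functional assay for antagonist activity at Adrenergic receptor alpha-1 (Rattus norvegicus) (a lower number here means tighter binding, a higher number weaker binding), while compound 2 `O=c1cc(-c2ccc(Cl)cc2)oc2cc(OCCCCN3CCN(c4ccccc4)CC3)ccc12` gives 12.2 nM in this assay. Compound 2 thus stands lowest of the two numbers, and the gap to compound 1 lies well beyond the usual scatter; the two compounds differ in more than one place, so no single change can be read from that gap.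

Compound 3 `Cc1ccc(N2CCN(CCCCOc3ccc4c(=O)cc(-c5ccc(Cl)cc5)oc4c3)CC2)cc1` has not yet been measured. It differs from compound 2 in one place only: methyl in place of hydrogen on an aromatic carbon. For the measured compounds named here, since no measured pair of compounds isolates this change, its effect is open. The step is expected to be small, from compound 2 to compound 3 by a 2.0-fold higher number from compound 2 to compound 3 (0.31 log units; beyond the scatter), possibly within the scatter. Compound 3 is therefore expected to give about 25 nM in this assay, within a range from 8 nM to 80 nM.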

Compound 3, dissociation constant: 3.18 nM
The estimate for compound 3 lay 7.9-fold (0.90 log units) above the measured number; measured number below the stated range.
By their numbers in this assay, from the lowest: compound 3; then compound 2; then compound 1.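

In this assay, methyl in place of hydrogen on an aromatic carbon, para to a large group, gives a 3.8-fold lower number from compound 2 to compound 3 (0.58 log units; beyond the scatter), so this position of the arylpiperazine end can take a methyl with a lower number, not a higher one. Adding the chloro, a change in a different place, gives a 61-fold lower number from compound 1 to compound 3 (1.79 log units; beyond the scatter), the first reading of that change on its own, and a larger step than the methyl gives. Nothing measured alongside these numbers bears on the reason for either step.

On these data alone, whether the methyl would bring a similar step in a compound without the chloro remains open, as does whether the chloro would bring a similar step without the methyl. Also open, as far as these compounds go, is how an ethyl, a methoxy or an amine at the same position would compare with the methyl.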